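The compounds below may be only part of what the source reports. "The series", "measured", "known", "first", "only" and "open" are said of these compounds alone.

Working notes on the series. In a functional assay on A-431 cells (Homo sapiens) for inhibition, read by MTT assay, with a stated time of 72 h (a lower number here means a stronger inhibitor, a higher number a weaker inhibitor), compound 1 `COc1cc2c(Nc3ccc([N+](=O)[O-])cc3)ncnc2c(OC)c1OC` gives 45200 nM. Compound 2 `COc1cc2c(Nc3cccc([N+](=O)[O-])c3)ncnc2c(OC)c1OC` gives 37700 nM in this assay. Going by the values given here, compound 3 `COc1cc2c(Nc3ccc(Cl)cc3)ncnc2c(OC)c1OC` gives 19000 nM in this assay, the lowest of the three numbers so far; its gap to compound 2 is within the scatter, its gap to compound 1 is beyond it. Among the compounds with values here, the single one-place step measured, a 2.4-fold lower number from compound 1 to compound 3 (0.38 log units; beyond the scatter), is modest.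

Compound 4 `COc1cc2c(Nc3cccc(Cl)c3)ncnc2c(OC)c1OC` has not yet been measured in this assay. It differs from compound 3 thus: 3-chlorophenyl in place of 4-chlorophenyl on a nitrogen on an aromatic ring. Within the data shown here, no measured step carries this change. The nearest comparison is the nitro pair, which differs in the same way: compound 1 gives 45200 nM, and compound 2 gives 37700 nM. Those two values lie within the scatter of each other. The expectation for compound 4 is therefore no step beyond the scatter, a 1.2-fold lower number from compound 3 to compound 4 (0.07 log units; within the scatter). Compound 4 is expected to give about 16000 nM, within a range from 7000 nM to 36000 nM.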

Compound 4, half-maximal inhibitory concentration: 32100 nM
Compound 4: the middle estimate sits 2.0-fold (0.30 log units) below what was measured; measured number inside the range.
By their numbers in this assay, from the lowest: compounds 3, 4, 2 and 1 (each within the scatter of the next, the first and the last beyond it).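

Moving the chloro from 4-chlorophenyl to 3-chlorophenyl on the nitrogen now has its own measured step in this assay, a 1.7-fold higher number from compound 3 to compound 4 (0.23 log units; within the scatter), so this change stays within the scatter with chloro, as it does with nitro. A second reading of chloro in place of nitro is also available, a 1.2-fold lower number from compound 2 to compound 4 (0.07 log units; within the scatter), and unlike the first reading it does not clear the scatter. Even so, the two readings cannot be told apart, so no dependence of this swap on the place of the group can be claimed: the same change on two cores in this assay, a 2.4-fold lower number (0.38 log units; beyond the scatter) from compound 1 to compound 3 and a 1.2-fold lower number (0.07 log units; within the scatter) from compound 2 to compound 4, 2.0-fold (0.31 log units) apart, within the scatter of two such steps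

Still open, from the compounds shown here alone, is whether an amine or a carboxylic acid in place of the chloro would give a step beyond the scatter at either place. Also open, going by these compounds, is whether a longer chain there would do so.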